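The source may report more compounds than this note shows. Statements on the series, on what has been measured and on what is new or still open speak of the compounds shown alone.

Measured so far in a functional assay on HT-29 cells (Homo sapiens) for inhibition, read by MTT assay, with a stated time of 72 h; a higher number here means a weaker inhibitor of growth, a lower number a stronger inhibitor of growth:

- compound 1, `CC(C)(C)c1ccc(CNCCNS(=O)(=O)c2cc(C(F)(F)F)cc(C(F)(F)F)c2)cc1`: 14000 nM
- compound 2, `COc1cccc(CNCCCNS(=O)(=O)c2cc(C(F)(F)F)cc(C(F)(F)F)c2)c1`: 10000 nM
- compound 3, `O=S(=O)(NCCCNCc1ccc(-c2ccccc2)cc1)c1cc(C(F)(F)F)cc(C(F)(F)F)c1`: 2300 nM

Compound 2 stands at the second highest of the three numbers. Compound 1 sits within the scatter of compound 2, so the two cannot be ordered. Compound 3 gives 2300 nM, a lower number that lies beyond the scatter from compound 2. For the measured compounds named here, no pair among the measured compounds differs in only one place, so no measured step is available to calibrate the change that follows.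

Compound 4, `COc1ccccc1CNCCCNS(=O)(=O)c1cc(C(F)(F)F)cc(C(F)(F)F)c1`, is the unmeasured member. Against compound 2 the difference is:

2-methoxyphenyl in place of 3-methoxyphenyl on a saturated chain carbon bound to an amine nitrogen

Going by the values given here, the series gives no measured step of this kind, and the only large gap present, between compound 2 and compound 3, concerns a different part of the molecule. Among the compounds with values here, with the same atoms joined differently and no precedent in the numbers, no step beyond the scatter is expected in this assay in either direction.

Compound 4 is therefore estimated at 10000 nM in this assay, with a range from 4000 nM to 25000 nM. The step of no change at the digits printed from compound 2 to compound 4 (within the scatter) is expected to stay within the scatter.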

Compound 4, concentration for 50% growth inhibition: 12000 nM
Beside the measured number, compound 4's estimate is 1.2-fold (0.08 log units) below it; low and high end bracket the measured number.
By their numbers in this assay, from the lowest: compound 3; then compounds 2, 4 and 1 (each within the scatter of the next).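

In this assay, the series now has its first step in which only one place differs: a 1.2-fold higher number from compound 2 to compound 4 (0.08 log units; within the scatter). With 2-methoxyphenyl in place of 3-methoxyphenyl on a saturated chain carbon bound to an amine nitrogen, the same atoms joined differently give no readable shift, so compound 2 and compound 4 cannot be ordered. No supporting data are available to explain this outcome.

The compounds shown leave open whether a different substituent on this phenyl ring, such as a hydroxyl group or a chlorine atom in place of methoxy, would give a step beyond the scatter. They also leave open whether the swap from 3-methoxyphenyl to 2-methoxyphenyl would read the same on a longer chain.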